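This account rests on a few compounds, and the source may have more. Where it says the series, first, only, none or still open, it means among the compounds named here.

Of the compounds shown here, three that share one core have been measured in a physicochemical assay for solubility, at pH 7.4; on this read-out higher numbers stand for higher solubility and lower numbers for lower solubility. Compound 1 `Cc1ccc(-c2cnc(C)n2C)cc1NC(=O)c1ccc(OCc2ccccn2)cc1` gives 371000 nM, and compound 2 `Cc1cc(C)c(-c2cn(C)cn2)cc1NC(=O)c1ccc(OCc2ccccn2)cc1` gives 8000 nM. Compound 3 `Cc1csc(-c2cc(NC(=O)c3ccc(OCc4ccccn4)cc3)c(C)cc2C)n1` returns in this assay only a limit, < 1000 nM, and not a number; it stands at the limit of < 1000 nM in this assay, at which 1 of the 3 values shown sits. For the measured compounds named here, the single measured step that alters one place, an at least 8.0-fold lower number from compound 2 to compound 3 (0.90 log units; beyond the scatter), moves the solubility down and ends at that limit. Compound 4 `Cc1cc(C)c(-c2ccccn2)cc1NC(=O)c1ccc(OCc2ccccn2)cc1` has not yet been measured; it differs from compound 3 by pyridin-2-yl in place of 4-methyl-1,3-thiazol-2-yl on an aromatic carbon. Going by the values given here, no measured step covers this exchange, and the earlier move from a methylimidazolyl to the methylthiazolyl does not show how a pyridinyl behaves in the same place. Because compound 3 already sits at the limit < 1000 nM, the expected step of an at least 1.5-fold higher number from compound 3 to compound 4 (0.17 log units; that floor lies within the scatter) can hardly point further down in a measurable way and is estimated to be small or upward. Compound 4 is therefore estimated at 1500 nM, within a range from 300 nM to 8000 nM, with a real chance that it too yields only a limit.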

Compound 4, solubility: < 1000 nM
Compound 4: a limit, no number; the forecaster's own chance of this, stated with the estimate: 40%; at least 1.5-fold (0.17 log units) between middle value and limit.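

In this assay, pyridin-2-yl in place of 1-methyl-1H-imidazol-4-yl gives an at least 8.0-fold lower number from compound 2 to compound 4 (0.90 log units; beyond the scatter), so on this aromatic carbon a drop now appears with a six-membered aromatic ring as well as with the five-membered 4-methyl-1,3-thiazol-2-yl. Compound 4 returns a limit and not a number, < 1000 nM. Compound 3 and compound 4 both stand at a limit, so the step between them cannot be read and neither group can be ranked against the other: the limit of < 1000 nM in this assay, at which 2 of the 4 values shown sit.

On these data alone, how far past the limit the true values of these two compounds lie remains open. Also open, as far as these compounds go, is what a group of a different kind, such as a carboxylic acid or a dimethylamino group, would give on this same aromatic carbon.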